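Trimethoxyphenyl pyrazole enones: halogen exchange on the aryl ketone

The compounds below may be only part of what the source reports. "The series", "measured", "known", "first", "only" and "open" are said of these compounds alone.

Measured so far in a functional assay on MCF7 cells (Homo sapiens) for inhibition, read by MTT assay, with a stated time of 48 h; on this read-out lower numbers stand for stronger inhibition and higher numbers for weaker inhibition:
compound 1 `COc1cc(-c2cc(/C=C3\CCc4ccccc4C3=O)[nH]n2)cc(OC)c1OC`: 8500 nM
compound 2 `COc1cc(-c2cc(/C=C/C(=O)c3ccc(Cl)cc3)[nH]n2)cc(OC)c1OC`: 11600 nM
compound 3 `COc1cc(C(=O)/C=C/c2cc(-c3cc(OC)c(OC)c(OC)c3)n[nH]2)cc(OC)c1OC`: 430 nM

Compound 2 gives the highest of the three numbers in this assay. Compound 1 sits nearest to it, and the gap between the two lies within the usual scatter, so no order between compound 1 and compound 2 can be read from these values. Compound 3 stands furthest away with a much lower number, a gap well beyond the scatter.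

Compound 4 `COc1cc(-c2cc(/C=C/C(=O)c3ccc(F)c(F)c3)[nH]n2)cc(OC)c1OC` has not yet been measured in this assay. It differs from compound 2 in one place: 3,4-difluorophenyl in place of 4-chlorophenyl on a carbonyl carbon. For the measured compounds named here, no pair of measured compounds shows what such an exchange of one halogenated aryl group for another does in this assay, so there is nothing in the data to anchor a direction. The step from compound 2 to compound 4 is therefore expected to be small, a 1.2-fold lower number from compound 2 to compound 4 (0.06 log units; within the scatter), and not beyond the scatter in either direction. Compound 4 is estimated at 10000 nM, with a range from 4000 nM to 25000 nM.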

Compound 4, half-maximal inhibitory concentration: 2500 nM
Beside the measured number, compound 4's estimate is 4.0-fold (0.60 log units) above it; measured number outside the range, below it.
By their numbers in this assay, from the lowest: compound 3; then compound 4; then compounds 1 and 2 (each within the scatter of the next).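

In this assay, 3,4-difluorophenyl in place of 4-chlorophenyl on the carbonyl carbon gives a 4.6-fold lower number from compound 2 to compound 4 (0.67 log units; beyond the scatter), a modest step. For the compounds shown here, the earlier compounds held no pair with a single exchange, so this is the first sign that the number responds to swapping one halogenated aryl group for another at this place. Nothing available bears on the reason for this step.

The compounds shown leave open whether the step follows the entering fluorine atoms or the leaving chlorine, as the two change together in this single exchange. Also open, on these data alone, is what a plain phenyl group, or a phenyl group carrying an amine or a carboxylic acid, would give on this carbonyl carbon.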